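Swapping the amino group of compound 2

The compounds below may be only part of what the source reports. "The series", "measured", "known", "first", "only" and "open" are said of these compounds alone.

In a physicochemical assay for solubility (a lower number here means a less soluble compound, a higher number a more soluble compound), compound 2 (`Cc1csc2cc([C@H](C)Nc3ncnc(N)c3C#N)c(Cc3cccc(CN)c3)c(=O)n12`) gives > 1000000 nM and this is a limit of the assay, not a number. It is the only one of the three measured compounds placed this way, as the limit of > 1000000 nM in this assay, at which 1 of the 3 values shown sits, makes plain. Compound 1 (`Cc1csc2cc([C@H](C)Nc3ncnc(N)c3C#N)c(Cc3cccc(CN4CCC4)c3)c(=O)n12`) gives 954000 nM in this assay while compound 3 (`Cc1csc2cc([C@H](C)Nc3ncnc(N)c3C#N)c(-c3ccccc3)c(=O)n12`) gives 77000 nM there.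

The change to compound 4 (`Cc1csc2cc([C@H](C)Nc3ncnc(N)c3C#N)c(Cc3cccc(CN(C)CC(C)C)c3)c(=O)n12`) is isobutyl(methyl)amino in place of amino on a saturated chain carbon bound to an aromatic carbon and it reads as isobutyl(methyl)amino in place of amino on a saturated chain carbon bound to an aromatic carbon. The nearest measured change at that place is an at least 1.0-fold higher number from compound 1 to compound 2 (0.02 log units; that floor lies within the scatter) and it bears most directly. The other measured change is an at least 12-fold lower number from compound 2 to compound 3 (1.11 log units; beyond the scatter) but it replaces the whole 3-(aminomethyl)benzyl with phenyl, so it bears only loosely.

A small fall is therefore expected, perhaps none beyond the scatter, since compound 1 still reaches 954000 nM with a substituted amine at that place. The estimated change is an at least 1.6-fold lower number from compound 2 to compound 4 (0.22 log units; that floor lies within the scatter) and it rests on that single comparison. Compound 4 is estimated at 600000 nM with an expected range of 200000 nM to 1000000 nM as its two ends.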

Compound 4, solubility: 12000 nM
For compound 4 the middle estimate is 50-fold (1.70 log units) above the measured one; measured number below the stated range.
By their numbers in this assay, from the lowest: compound 4; then compound 3; then compound 1. At a limit, above all of these: compound 2.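

At the saturated chain carbon bound to an aromatic carbon, the result shows that the choice of substituted amine matters in this assay: the earlier pair gave only an at least 1.0-fold higher number from compound 1 to compound 2 (0.02 log units; that floor lies within the scatter), whereas isobutyl(methyl)amino in place of azetidin-1-yl gives an 80-fold lower number from compound 1 to compound 4 (1.90 log units; beyond the scatter). Against the free amino group the change is also large, an at least 83-fold lower number from compound 2 to compound 4 (1.92 log units; beyond the scatter). That step is a floor, and the value of compound 2 is a limit of the assay and not a number: the limit of > 1000000 nM in this assay, at which 1 of the 4 values shown sits.

The compounds shown do not separate the isobutyl chain from the methyl on the same nitrogen as the source of this fall. Going by these compounds, whether an open-chain amine such as dimethylamino, or a ring amine such as morpholin-4-yl, would read nearer compound 1 or nearer compound 4 also stays open.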